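Swapping a Ring for an Open Chain

The source may report more compounds than this note shows. Statements on the series, on what has been measured and on what is new or still open speak of the compounds shown alone.

Compound 1 `Clc1ccc2c(N3CCN(CCN4CCCCCC4)CC3)ccnc2c1`: 25400 nM
Compound 2 `O=C(CN1CCCC1)NCCNc1ccnc2cc(Cl)ccc12`: 46400 nM

Both values come from a toxicity assay (L6 cells) for inhibition, with Rattus norvegicus as the target, read by resazurin assay, with a stated time of 70 h; a higher number here means a weaker inhibitor, a lower number a stronger inhibitor. Among the compounds with values here, they lie within the usual scatter of each other, so compound 1 cannot be ranked above or below compound 2, the only other compound measured so far.

Compound 3 `CCCN(CCC)CCN1CCN(c2ccnc3cc(Cl)ccc23)CC1` has not yet been measured. It differs from compound 1 in one place, with dipropylamino in place of azepan-1-yl on a saturated chain carbon, two bonds along the chain from an amine nitrogen in a ring. Within the data shown here, no measured pair shows what this swap does, so the expectation starts from compound 1 at 25400 nM. The estimated step, a 1.1-fold lower number from compound 1 to compound 3 (0.02 log units; within the scatter), is expected to stay within the usual scatter, with neither direction favoured. For compound 3 the estimated value is 24000 nM, with an expected range from 10000 nM to 55000 nM.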

Compound 3, half-maximal inhibitory concentration: 56800 nM
Estimate against measurement, compound 3: 2.4-fold (0.37 log units) below; measured number outside the range, above it.
By their numbers in this assay, from the lowest: compounds 1, 2 and 3 (each within the scatter of the next, the first and the last beyond it).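

Replacing azepan-1-yl with dipropylamino gives a 2.2-fold higher number from compound 1 to compound 3 (0.35 log units; beyond the scatter) in this assay and so a modest loss of inhibition. Within the data shown here, this is the first step that can be read at this position on the chain. Both groups have 7 heavy atoms, including 1 nitrogen, and the counted hydrogen-bond donors and acceptors match, so the ring is the listed difference and the result shows that this position is sensitive to the change from ring to open chain. Nothing available explains why the number rises.

This single swap leaves open whether a smaller ring, such as piperidin-1-yl, would stay close to compound 1. It also leaves open whether a shorter open group, such as diethylamino, would match compound 3 or differ from it.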